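A few compounds are considered here, and "the series" means these few. Any claim that something is new, unique, unknown or untested is made for them only; others in the source may bear on it.

In an assay on membranes from lung (Cavia porcellus) for binding affinity to cysteinyl leukotriene receptor (Homo sapiens) (on this read-out lower numbers stand for stronger inhibition and higher numbers for weaker inhibition), compound 1 `CCCCCCCCCCCCc1ccccc1C(SCCC(=O)O)SCCC(=O)O` gives 445 nM, compound 2 `CCCCC/C=C/C/C=C/COc1ccccc1C(SCCC(=O)O)SCCC(=O)O` gives 1000 nM, and compound 3 `O=C(O)CCSC(SCCC(=O)O)c1ccccc1OCCCCCCc1ccccc1` gives 11500 nM. Compound 3 thus carries the highest number of the three, and its distance from compound 2 as well as from compound 1 lies beyond the usual scatter of this assay. Compound 4 `CCOCCOCCOCCOc1ccccc1C(SCCC(=O)O)SCCC(=O)O` differs from compound 3 in a single place: 2-(2-ethoxyethoxy)ethoxy in place of 4-phenylbutyl on a saturated chain carbon, two bonds along the chain from an oxygen on an aromatic ring. For the measured compounds named here, no measured pair shows a change of this kind, so the expectation rests on compound 3 alone, which already gives 11500 nM. The expected step is a 1.4-fold higher number from compound 3 to compound 4 (0.14 log units; within the scatter), a modest move toward a higher number that may not exceed the scatter. Compound 4 is therefore estimated at 16000 nM, within a range from 4000 nM to 60000 nM.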

Compound 4, inhibition constant: > 20000 nM
Compound 4 ended at the assay's limit; the forecaster's own chance of this, stated with the estimate: 25%; middle value at least 1.2-fold (0.09 log units) from the limit.
By their numbers in this assay, from the lowest: compound 1; then compound 2; then compound 3. At a limit, above all of these: compound 4.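

In this assay compound 4 sits at a limit, not at a true number: the limit of > 20000 nM in this assay, at which 1 of the 4 values shown sits. Replacing the deca-1,4-dien-1-yl-bearing side chain with the oxygen-rich one gives an at least 20-fold higher number from compound 2 to compound 4 (1.30 log units; beyond the scatter), so at this place an all-carbon chain and this ether chain are clearly not interchangeable. Against the 4-phenylbutyl group the change gives an at least 1.7-fold higher number from compound 3 to compound 4 (0.24 log units; that floor lies within the scatter), so the limit does not show that this swap costs anything beyond compound 3's already weak result. Going by these compounds, whether an amine or a carboxylic acid in this place would bring the number down remains open.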